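The compounds below may be only part of what the source reports. "The series", "measured", "known", "first", "only" and "open" are said of these compounds alone.

Measured compounds:
- compound 1, `Cc1ccc(-c2cc(=O)c3ccc(C)cc3o2)cc1`, giving 40% in an in vitro assay on BTI-TN-5B1-4 cells for inhibition of Amine oxidase [flavin-containing] A (Homo sapiens), tested at 100 uM; on this read-out lower numbers stand for less inhibition and higher numbers for more inhibition at the one concentration tested (going by the name of the read-out)
- compound 2, `COc1ccc(-c2cc(=S)c3ccc(F)cc3o2)cc1`, reported as "not active" (no number reported) in this assay
- compound 3, `COc1ccc(-c2cc(=O)c3ccc(C)cc3o2)cc1`, giving 40% in this assay

Compound 3 and compound 1 differ by one change, (methyl in place of methoxy on an aromatic carbon). This step, no change at the digits printed from compound 3 to compound 1 (within the scatter), lies within the scatter, so the two values say nothing about an order between them.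

Compound 4, `Cc1ccc(-c2cc(=S)c3ccc(F)cc3o2)cc1`, has not been measured. It differs from compound 2 by methyl in place of methoxy on an aromatic carbon, which is the same change, at a place described in the same words, as that from compound 3 to compound 1. The difference between the core of compound 2 and the core of compound 3 is not broken down here.

For compound 2 no number is known, only that it was reported as "not active" (no number reported). Since the same change made no measurable difference from compound 3 to compound 1, compound 4 is expected to stay near compound 2 in this assay. Compound 4 is therefore estimated at 10%, between 0% and 30%, because no change at the digits printed from compound 3 to compound 1 (within the scatter) suggests the change carries little weight here.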

Compound 4, a percentage reported as inhibition, at one concentration (the size of the read-out at that concentration, not a potency): 40%
Estimate against measurement, compound 4: 30 percentage points below; the measured number lies above the stated range.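

Going by these compounds alone, compound 2 was reported only as "not active" with no number in this assay, so no step to compound 4, at 40%, can be read. Nothing shown here offers an explanation for this result. The compounds shown leave open how the core of compound 4 and the core of compound 1 compare, as these two differ in more than one place.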